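Compound 4: an amino chain in place of an aryl amide

A few compounds are considered here, and "the series" means these few. Any claim that something is new, unique, unknown or untested is made for them only; others in the source may bear on it.

Measured compounds:
compound 1 `CC(=O)Oc1ccccc1C1CC(C)=NN1C(=O)CN(C(C)C)C(C)C` gives 24500 nM
compound 2 `CC(=O)Oc1ccccc1C1CC(C)=NN1C(=O)CN1CCC(C(C)=O)CC1` gives 6800 nM
compound 3 `Cc1ccc(C(=O)N2N=C(c3cc4ccccc4oc3=O)CC2c2ccccc2)cc1` gives 13200 nM

In a functional assay on PC-3 cells (Homo sapiens) for cytotoxicity, read by MTT assay, with a stated time of 48 h (a lower number here means a stronger inhibitor, a higher number a weaker inhibitor), compound 3 gives 13200 nM, the second highest of the three numbers. Its nearest neighbour is compound 1, and the gap between the two lies within the scatter; the gap to compound 2 is also within the scatter, so no order among the three can be read from these values.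

Compound 4 `CCNCC(=O)N1N=C(c2cc3ccccc3oc2=O)CC1c1ccccc1` differs from compound 3 in one place: (ethylamino)methyl in place of 4-methylphenyl on a carbonyl carbon. Among the measured compounds shown here, the only measured step is a 3.6-fold lower number from compound 1 to compound 2 (0.56 log units; beyond the scatter), and it touches a different part of the molecule, the amine on a chain that already sits on the carbonyl; it shows that changes at the amine end of such a chain can move the number modestly. For the measured compounds named here, no measured pair shows the exchange of an aryl amide for an aminoacetyl-type chain, so the direct bearing on compound 4 is weak. Compounds 1 and 2 both carry such a chain and sit within the same broad range as compound 3. Compound 4 is therefore expected to give a number close to that of compound 3, with at most a modest lowering, a 1.5-fold lower number from compound 3 to compound 4 (0.17 log units; within the scatter). The estimate for compound 4 is 9000 nM, with a range from 3000 nM to 27000 nM.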

Compound 4, half-maximal inhibitory concentration: 5580 nM
Compound 4: the middle estimate sits 1.6-fold (0.21 log units) above what was measured; the measured number falls inside the stated range.
By their numbers in this assay, from the lowest: compounds 4, 2, 3 and 1 (each within the scatter of the next, the first and the last beyond it).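

In this assay, putting (ethylamino)methyl in place of 4-methylphenyl on the carbonyl carbon gives a 2.4-fold lower number from compound 3 to compound 4 (0.37 log units; beyond the scatter), a modest step beyond the scatter. Among the compounds shown here, this is the first measured change on the shared core of compounds 3 and 4, whereas the only earlier step concerned the amine on a chain in a different core. It shows that this position responds to substitution and that, in this pair, the six-membered aromatic ring of 4-methylphenyl is not needed to reach the lower number, although the pair cannot separate losing that ring from gaining the amine nitrogen, and no supporting measurement explains the step.

On these data alone, what remains open is whether the amine nitrogen itself matters, which a plain propyl chain on the same carbonyl carbon would test, and whether a dimethylamino, diisopropylamino or 4-acetylpiperidin-1-yl group would move the number on this core as the amine change did on the other. Also open, as far as these compounds go, is how a longer chain between the carbonyl and the ethylamino nitrogen would read.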